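The source may hold more compounds than are shown below. What is called first, only, known or untested is meant among the compounds shown, and "the series" means these compounds.

Measured compounds in a functional assay on HCT-116 cells (Homo sapiens) for cytotoxicity, read by MTT assay, with a stated time of 72 h; on this read-out lower numbers stand for higher toxicity in this test and higher numbers for lower toxicity in this test:

compound 1 `COc1ccc2c(c1)c(O)c(C(=O)O)c(=O)n2C`: > 10000 nM
compound 2 `Cn1c(=O)c(C(=O)O)c(O)c2cc(Cc3ccccc3)ccc21`: > 10000 nM
compound 3 `CCOC(=O)c1c(O)c2cc(OC)ccc2n(C)c1=O`: > 10000 nM

Each of these values is a limit of this assay and not a number; compound 1 gives > 10000 nM as a limit. Compound 2 gives > 10000 nM as a limit. Compound 3 gives > 10000 nM as a limit. All three sit at the limit of > 10000 nM in this assay, at which 3 of the 3 values shown sit.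

Compound 1 to compound 2 carries benzyl in place of methoxy on an aromatic carbon, giving a step that the two limits leave unreadable from compound 1 to compound 2. Compound 1 to compound 3 carries ethyl in place of hydrogen on an oxygen next to a carbonyl group, giving a step that the two limits leave unreadable from compound 1 to compound 3.

Compound 4 `CCOC(=O)c1c(O)c2cc(Cc3ccccc3)ccc2n(C)c1=O` is not yet measured in this assay. From compound 3 it carries benzyl in place of methoxy on an aromatic carbon, the same change as from compound 1 to compound 2, made on the core of compound 3 rather than the core of compound 1.

The step from compound 3 to compound 4 is expected near a step that the limit leaves unreadable from compound 3 to compound 4, resting on compound 2 having given > 10000 nM and compound 3 having given > 10000 nM. Compound 4 is expected at 15000 nM, between 7000 nM and 40000 nM, most likely again a limit.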

Compound 4, half-maximal cytotoxic concentration: > 10000 nM
Compound 4: no number, only a limit (the forecaster's own chance of this, stated with the estimate: 85%); the middle value is on the limit's open side.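

Compound 4 gives > 10000 nM as a limit and not a number, so the steps to it from compound 3 and from compound 2 cannot be read. The compounds shown leave open whether benzyl in place of methoxy, or ethyl in place of hydrogen, changes the read-out in this assay at all: the limit of > 10000 nM in this assay, at which 4 of the 4 values shown sit.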